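Series notes: methoxy for hydroxymethyl on the cyclohexyl ring

The compounds below may be only part of what the source reports. "The series", "measured", "known", "first", "only" and "open" are said of these compounds alone.

Of the compounds shown here, three of the shared core have been measured. Compound 1 `Nc1ncnc2c1c(Oc1cc(C(F)(F)F)ccn1)nn2[C@H]1C[C@H](F)C1` gives 2.03 h in an ADME assay on microsomes from liver (Homo sapiens) for metabolic stability, read by LC-MS, using NADPH, with a stated time of 10 min, tested at 10 uM; on this read-out lower numbers stand for a shorter-lived compound and higher numbers for a longer-lived compound. Compound 2 `Nc1ncnc2c1c(Oc1cc(C(F)(F)F)ccn1)nn2[C@H]1CC[C@@H](CO)CC1` gives 1.6 h in this assay, and compound 3 `Nc1ncnc2c1c(Oc1cc(O)ccn1)nn2[C@H]1C[C@H](F)C1` gives 1.03 h. On these numbers compound 2 holds the second highest value, with compound 1 nearest a 1.3-fold lower number from compound 1 to compound 2 (0.10 log units; within the scatter) and compound 3 furthest; both gaps sit within the scatter, so no order among the three can be read.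

Compound 4 `CO[C@H]1CC[C@@H](n2nc(Oc3cc(C(F)(F)F)ccn3)c3c(N)ncnc32)CC1` is not yet measured. It differs from compound 2 in one place: methoxy in place of hydroxymethyl on a saturated ring carbon

Of the measured steps, the exchange of the substituent on the aromatic nitrogen a 1.3-fold lower number from compound 1 to compound 2 (0.10 log units; within the scatter) is the only one that touches the same region, and it stayed within the scatter; the step on the aromatic carbon a 2.0-fold lower number from compound 1 to compound 3 (0.29 log units; within the scatter) also stayed within the scatter and does not bear on this change directly. Among the measured compounds shown here, no measured step removes a hydroxyl from the saturated ring substituent. The step expected in this assay is therefore small, without a clear direction: a 1.1-fold lower number from compound 2 to compound 4 (0.03 log units; within the scatter). Compound 4 is estimated at 1.5 h, with a range from 0.8 h to 3 h.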

Compound 4, half-life: 0.317 h
Compound 4: middle estimate off by 4.7-fold (0.68 log units), on the high side, outside the stated range (below it).
By their numbers in this assay, from the lowest: compound 4; then compounds 3, 2 and 1 (each within the scatter of the next).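

In this assay, methoxy in place of hydroxymethyl on this saturated ring carbon gives a 5.0-fold lower number from compound 2 to compound 4 (0.70 log units; beyond the scatter), so a change that keeps the same atoms but joins them differently is enough to produce a step beyond the scatter here. The larger ring on the aromatic nitrogen does not go with such a step by itself: 4-(hydroxymethyl)cyclohexyl stays within the scatter (a 1.3-fold lower number from compound 1 to compound 2 (0.10 log units; within the scatter)), whereas 4-methoxycyclohexyl in place of 3-fluorocyclobutyl gives a 6.4-fold lower number from compound 1 to compound 4 (0.81 log units; beyond the scatter). Nothing available explains this step.

Hydroxymethyl carries a hydrogen-bond donor and methoxy none, but the compounds shown cannot separate that count from the altered connectivity. Also open, going by these compounds, is where an amine, a carboxylic acid or a longer chain such as ethoxy on this ring carbon would stand.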